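Replacing 6-methoxypyridin-3-yl with 4-ethoxyphenyl on a shared core

A few compounds are considered here, and "the series" means these few. Any claim that something is new, unique, unknown or untested is made for them only; others in the source may bear on it.

Compound 1 `COc1ccc(-c2cc3c(cn2)[nH]c(=O)n3-c2cc(OC)c(OC)c(OC)c2)cc1` gives 1210 nM
Compound 2 `COc1ccc(-c2cc3c(cn2)[nH]c(=O)n3-c2cc(OC)c(OC)c(OC)c2)cc1O` gives 490 nM
Compound 3 `COc1ccc(-c2cc3c(cn2)[nH]c(=O)n3-c2cc(OC)c(OC)c(OC)c2)cn1` gives 870 nM

These values come from a functional assay on HeLa cells (Homo sapiens) for antiproliferative activity, read by MTT assay, with a stated time of 48 h (a lower number here means a stronger inhibitor, a higher number a weaker inhibitor), and all three compounds share one core. Compound 3 holds the middle place among the three numbers, yet its gaps to the other two are small. The measured steps are a 1.4-fold lower number from compound 1 to compound 3 (0.14 log units; within the scatter) and a 1.8-fold higher number from compound 2 to compound 3 (0.25 log units; within the scatter) and neither exceeds the usual noise.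

The next compound is compound 4 `CCOc1ccc(-c2cc3c(cn2)[nH]c(=O)n3-c2cc(OC)c(OC)c(OC)c2)cc1` with 4-ethoxyphenyl in place of 6-methoxypyridin-3-yl on an aromatic carbon and this change swaps one ring type for another while also altering the chain on its oxygen. The step between compound 1 and compound 3 bears most directly on the ring swap, and it stayed within the scatter. Among the measured compounds shown here, the one clear step, a 2.5-fold lower number from compound 1 to compound 2 (0.39 log units; beyond the scatter), added a hydroxy group that compound 4 does not carry, so it says little here. For the measured compounds named here, no measured pair shows what ethoxy does in place of methoxy, and that gap widens the range.

No step beyond the scatter is therefore expected in this assay and the expected step is a 1.4-fold higher number from compound 3 to compound 4 (0.14 log units; within the scatter) here. Compound 4 is estimated at 1200 nM with an expected range from 450 nM to 3200 nM overall.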

Compound 4, half-maximal inhibitory concentration: 3730 nM
Beside the measured number, compound 4's estimate is 3.1-fold (0.49 log units) below it; the measured number lies above the stated range.
By their numbers in this assay, from the lowest: compounds 2, 3 and 1 (each within the scatter of the next, the first and the last beyond it); then compound 4.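

Adding one methyl to the chain on the oxygen, with nothing else changed, gives a 3.1-fold higher number from compound 1 to compound 4 (0.49 log units; beyond the scatter) in this assay, and this is the first change on this aromatic carbon seen to weaken activity beyond the scatter. The other two new steps point the same way, a 4.3-fold higher number from compound 3 to compound 4 (0.63 log units; beyond the scatter) and a 7.6-fold higher number from compound 2 to compound 4 (0.88 log units; beyond the scatter), so 4-ethoxyphenyl stands apart from all three earlier groups at this position. Among these compounds, 4-methoxyphenyl and 6-methoxypyridin-3-yl could be exchanged with no change beyond the scatter, whereas the slightly longer chain on the oxygen could not.

No measurement shown explains this loss of activity. From the compounds shown here alone, it remains open whether a still longer propoxy chain, a branched isopropoxy group or an amine-bearing chain on the same oxygen would weaken activity further, and whether an ethoxy in place of the methoxy on the pyridine ring of compound 3 or on the hydroxy-bearing ring of compound 2 would bring the same loss.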